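The compounds below may be only part of what the source reports. "The series", "measured", "known", "first", "only" and "open" are said of these compounds alone.

Measured compounds:
Compound 1 `C=C[C@@](C)(/C=C/c1ccc(OCc2ccccc2)cc1)CCC=C(C)C` — in a functional assay on NALM-6 cells (Homo sapiens) for cytotoxicity, with a stated time of 72 h (a higher number here means that more compound is needed for the effect, a lower number that less compound is needed), compound 1 gives > 43400 nM, which is a limit of the assay and not a number.
Compound 2 `C=C[C@@](C)(/C=C/c1ccc(O)c(/C=C/C(=O)NCc2ccc(C(F)(F)F)cc2)c1)CCC=C(C)C` — in this assay compound 2 gives > 43400 nM, again a limit.
Compound 3 `C=C[C@@](C)(/C=C/c1ccc(Nc2cc(F)c(F)c(F)c2)cc1)CCC=C(C)C` — in this assay compound 3 gives > 43400 nM, again a limit.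

Compound 1 therefore stands nowhere on a scale of numbers: there is only a limit for it, and the two further values shown are limits as well, so that (the limit of > 43400 nM in this assay, at which 3 of the 3 values shown sit). Going by the values given here, no step between measured compounds can be drawn from these three values, and nothing in them points in one direction or another; they show only that none of the three reached the read-out within the tested range.

Compound 4 `C=C[C@@](C)(/C=C/c1ccc(-c2ccc(F)cc2)cc1)CCC=C(C)C` differs from compound 1 in a single place: 4-fluorophenyl in place of benzyloxy on an aromatic carbon. The benzyloxy group leaves and 4-fluorophenyl enters, on an aromatic carbon of the six-membered aromatic ring of carbon only, para to a large group.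

With every measured value sitting at the same limit, no shown step supports a change of any size, and the step that the limit leaves unreadable from compound 1 to compound 4 is expected to be none beyond the scatter. Compound 4 is estimated at 60000 nM, with a range from 20000 nM to 200000 nM, and is most likely to be reported once more as a limit rather than a number.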

Compound 4, half-maximal effective concentration: > 43400 nM
Compound 4 ended at the assay's limit; the forecaster's own chance of this, stated with the estimate: 80%; the middle value is on the limit's open side.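

No step can be read from compound 1 to compound 4 in this assay, where 4-fluorophenyl in place of benzyloxy leaves both compounds at a limit and not at a number: the limit of > 43400 nM in this assay, at which 4 of the 4 values shown sit. The compounds shown leave open whether any change on the shared core gives a value inside the tested range.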